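The source may report more compounds than this note shows. Statements on the series, on what has been measured and on what is new or still open speak of the compounds shown alone.

Measured so far:
Compound 1 `C/C=C/[C@@H](CC(=O)O)NC(=O)[C@@H]1CCCN1S(=O)(=O)c1cc(Cl)cc(Cl)c1` gives 13 nM in an assay on RPMI-8866 cells for inhibition of integrin alpha-4/beta-1 (Homo sapiens); on this read-out higher numbers stand for weaker inhibition and lower numbers for stronger inhibition.
Compound 2 `O=C(O)CCNC(=O)[C@@H]1CCCN1S(=O)(=O)c1cc(Cl)cc(Cl)c1` gives 1510 nM in this assay.
Compound 3 `O=C(O)C[C@@H](NC(=O)[C@@H]1CCN1S(=O)(=O)c1cc(Cl)cc(Cl)c1)c1ccc(F)cc1` gives 3.2 nM in this assay.

Compound 3 stands lowest of the three, and both gaps, to compound 1 and the far larger one to compound 2, lie beyond the scatter, so on these numbers it is the strongest inhibitor of the set. Compound 4 `O=C(O)C[C@@H](NC(=O)[C@@H]1CCN1S(=O)(=O)c1cc(Cl)cc(Cl)c1)c1ccc(Br)cc1` differs from compound 3 in one place: bromo in place of fluoro on an aromatic carbon. Its number in this assay is not yet known.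

For the measured compounds named here, only one measured step exists here, a 120-fold higher number from compound 1 to compound 2 (2.07 log units; beyond the scatter), and it concerns the loss of a whole chain group beside the acid-bearing carbon, not a swap of one halogen for another on the aromatic ring. Going by the values given here, no measured pair in this set changes the halogen on the aromatic ring, so there is no direct precedent for the move from fluoro to bromo. Since what enters and what leaves are each a single atom with no donors, acceptors or charge, the expected step of a 1.1-fold higher number from compound 3 to compound 4 (0.04 log units; within the scatter) is small, with no clear direction beyond the scatter. Compound 4 is therefore estimated at 3.5 nM in this assay, within a range from 1.2 nM to 10 nM.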

Compound 4, half-maximal inhibitory concentration: 2.1 nM
The estimate for compound 4 lay 1.7-fold (0.22 log units) above the measured number; low and high end bracket the measured number.
By their numbers in this assay, from the lowest: compounds 4 and 3 (each within the scatter of the next); then compound 1; then compound 2.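

In this assay, bromo in place of fluoro on an aromatic carbon, para to a large group, gives a 1.5-fold lower number from compound 3 to compound 4 (0.18 log units; within the scatter) and so leaves the two halogens indistinguishable on this read-out. For the compounds shown here, the only earlier step, a 120-fold higher number from compound 1 to compound 2 (2.07 log units; beyond the scatter), concerned the loss of a whole chain group, whereas this is the first measured change on the aromatic ring, and it shows that inhibition stays in the same low range with either 4-fluorophenyl or 4-bromophenyl in place. Nothing available here accounts for why the two halogens read alike.

On these data alone, what this position does with a group other than a halogen stays open: a hydrogen, a methoxy group, an amine or a carboxylic acid on the same carbon could each behave quite differently from fluoro and bromo. Two halogens on one core also leave open whether chloro or iodo would read the same, and whether this swap would stay as quiet on a different core.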